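A Phenyl Swap at the Limit of the Assay

The compounds below may be only part of what the source reports. "The series", "measured", "known", "first", "only" and "open" are said of these compounds alone.

Compound 1 `COc1ccc(-c2c[nH]c(=O)n2-c2cc(OC)c(OC)c(OC)c2)cc1`: > 50000 nM (a limit)
Compound 2 `COc1cc(-n2c(-c3ccc(Cl)cc3)cn(C(C)=O)c2=O)cc(OC)c1OC`: > 50000 nM (a limit)

The test here is a functional assay on ECa-109 cells (Homo sapiens) for cytotoxicity, read by MTT assay, with a stated time of 48 h; a higher number here means a weaker inhibitor, a lower number a stronger inhibitor. In this assay, compound 2 gives > 50000 nM, which is a limit of the assay and not a number. Compound 1 likewise gives only a limit, > 50000 nM. Compound 2 therefore stands with compound 1 at the limit of > 50000 nM in this assay, at which 2 of the 2 values shown sit.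

Compound 3 `COc1cc(-n2c(-c3ccc(F)cc3F)cn(C(C)=O)c2=O)cc(OC)c1OC` keeps the acetyl group of compound 2 and carries 2,4-difluorophenyl in place of 4-chlorophenyl on an aromatic carbon. Among the measured compounds shown here, no measured step shows what a change of this kind does in this assay, so no shift beyond the usual scatter is expected, and another limit is the likeliest result. The expected size of the change is a number no higher from compound 2 to compound 3 (the limit leaves the size open). Compound 3 is estimated at 50000 nM, with an expected range of 12000 nM to 100000 nM.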

Compound 3, half-maximal inhibitory concentration: > 50000 nM
Compound 3: no number, only a limit (the forecaster's own chance of this, stated with the estimate: 70%); the middle value lies on the limit itself.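

Compound 2 and compound 3 both end at a limit of the assay and not at a number, so the step between them cannot be read. Still open is how strongly any compound shown acts, and which change would alter that, for all stand together: the limit of > 50000 nM in this assay, at which 3 of the 3 values shown sit.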